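This account rests on a few compounds, and the source may have more. Where it says the series, first, only, none or still open, it means among the compounds named here.

Compound 1 `CCCSc1nc(Cl)c2c(n1)N(Cc1ccccc1)C(C(=O)NCCNC(=O)OC(C)(C)C)N2` carries a (2-((tert-butoxycarbonyl)amino)ethyl)amino group on a carbonyl carbon. In a functional assay on MGC-803 cells (Homo sapiens) for antiproliferative activity, read by MTT assay, with a stated time of 72 h (on this read-out lower numbers stand for stronger inhibition and higher numbers for weaker inhibition), compound 1 gives only a limit of the assay, > 64000 nM, and no number. Compound 2 `CCCSc1nc(Cl)c2c(n1)N(Cc1ccccc1)C(C(=O)OCC)N2` has ethoxy in that place instead, and in this assay compound 2 gives 18500 nM. On the numbers shown, compound 2 therefore stands as the single measured value, the other result being a limit. Among the measured compounds shown here, the one step available, an at least 3.4-fold lower number from compound 1 to compound 2 (0.53 log units; beyond the scatter), is open at its far end because of the limit of > 64000 nM in this assay, at which 1 of the 2 values shown sits. Compound 3 `CCCSc1nc(Cl)c2c(n1)N(Cc1ccccc1)C(C(=O)NCCCc1ccccc1)N2` differs from compound 2 by (3-phenylpropyl)amino in place of ethoxy on a carbonyl carbon. The measured step bears on this only in part: it shows that exchanging an amide for the ester made compound 2 at least modestly stronger, while compound 3 returns to an amide, though with a quite different chain ending in an aromatic ring. The expected step in this assay is therefore a 1.6-fold higher number from compound 2 to compound 3 (0.21 log units; within the scatter), modest toward a higher number or none beyond the scatter. For compound 3 the estimate in this assay is 30000 nM, within a range of 9000 nM to 100000 nM.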

Compound 3, half-maximal inhibitory concentration: 16900 nM
Estimate against measurement, compound 3: 1.8-fold (0.25 log units) above; measured number inside the range.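

Exchanging ethoxy for (3-phenylpropyl)amino on this carbonyl carbon brings in a six-membered aromatic ring and a hydrogen-bond donor, yet in this assay the result is a 1.1-fold lower number from compound 2 to compound 3 (0.04 log units; within the scatter), so this place accepts the much larger group with no change beyond the scatter. The earlier step left open whether the amide itself went with the weaker result, but compound 3 is also an amide, and the step of an at least 3.7-fold lower number from compound 1 to compound 3 (0.57 log units; beyond the scatter), with benzyl in place of (tert-butoxycarbonyl)amino on a saturated chain carbon, two bonds along the chain from an amide-type nitrogen, points instead to what the amide chain carries. That step gives only a minimum, and its true size stays unknown, for one end of it is a limit and not a number: the limit of > 64000 nM in this assay, at which 1 of the 3 values shown sits.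

The compounds shown do not tell how a free amine at the end of the amide chain, a carboxylic acid on this carbonyl carbon, or a shorter or longer chain leading to the phenyl ring would read in this assay. The rest of the core is the same in all three compounds, so they say nothing about changes made there.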